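The source may report more compounds than this note shows. Statements on the series, on what has been measured and on what is new or still open speak of the compounds shown alone.

Three compounds have been measured so far in a functional assay on A549 cells (Homo sapiens) for cytotoxicity, read by MTT assay, with a stated time of 72 h; a higher number here means a weaker inhibitor, a lower number a stronger inhibitor:

Compound 1 `CC1CCN(Cc2ccc3nc(NC(=O)N/N=C/c4cn(Cc5ccc(Cl)cc5Cl)c5ccccc45)sc3c2)CC1` gives 3640 nM.
Compound 2 `CCN(CC)Cc1ccc2nc(NC(=O)N/N=C/c3cn(Cc4ccc(Cl)cc4Cl)c4ccccc34)sc2c1` gives 1900 nM.
Compound 3 `CCN(CC)Cc1ccc2nc(NC(=O)N/N=C/c3cn(Cc4ccccc4)c4ccccc34)sc2c1` gives 3330 nM.

All three share one core and differ at two ends of it. Between compound 2 and compound 1 the change is 4-methylpiperidin-1-yl in place of diethylamino on a saturated chain carbon bound to an aromatic carbon, and it made a step of a 1.9-fold higher number from compound 2 to compound 1 (0.28 log units; within the scatter). Between compound 2 and compound 3 the change is phenyl in place of 2,4-dichlorophenyl on a saturated chain carbon bound to an aromatic nitrogen, with a step of a 1.8-fold higher number from compound 2 to compound 3 (0.24 log units; within the scatter). Compound 4 `CC1CCN(Cc2ccc3nc(NC(=O)N/N=C/c4cn(Cc5ccccc5)c5ccccc45)sc3c2)CC1` has not yet been measured. It carries the change (4-methylpiperidin-1-yl in place of diethylamino on a saturated chain carbon bound to an aromatic carbon), made on the core of compound 3; this is the same change that turned compound 2 into compound 1, at the same place, and among the compounds shown it occurs twice in all. The step is expected to be a 1.7-fold higher number from compound 3 to compound 4 (0.22 log units; within the scatter), a small one, because the earlier step of a 1.9-fold higher number from compound 2 to compound 1 (0.28 log units; within the scatter) stayed within the scatter of this kind of measurement, and nothing else here suggests a larger shift. For compound 4 the number is therefore estimated at 5500 nM, with a likely range from 2500 nM to 12000 nM.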

Compound 4, half-maximal inhibitory concentration: 2340 nM
Compound 4: middle estimate off by 2.4-fold (0.37 log units), on the high side; the whole stated range lies above it.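

In this assay, putting 4-methylpiperidin-1-yl in place of diethylamino on the core of compound 3 gave a 1.4-fold lower number from compound 3 to compound 4 (0.15 log units; within the scatter), and this step does not match the one the same change gave on the other core: the same change on two cores in this assay, a 1.9-fold higher number (0.28 log units; within the scatter) from compound 2 to compound 1 and a 1.4-fold lower number (0.15 log units; within the scatter) from compound 3 to compound 4, 2.7-fold (0.44 log units) apart, beyond the scatter of two such steps Putting phenyl in place of 2,4-dichlorophenyl, which gave a 1.6-fold lower number from compound 1 to compound 4 (0.19 log units; within the scatter), shows the same mismatch with its earlier step: the same change on two cores in this assay, a 1.8-fold higher number (0.24 log units; within the scatter) from compound 2 to compound 3 and a 1.6-fold lower number (0.19 log units; within the scatter) from compound 1 to compound 4, 2.7-fold (0.44 log units) apart, beyond the scatter of two such steps Among these four compounds, neither change carries over as a fixed step from one core to the other, yet each single step lies within the scatter, and the data show neither that one change alone shifts the number nor why the two cores differ.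

The compounds shown leave open how other amines, such as morpholin-4-yl or piperidin-1-yl without the methyl group, would behave on a saturated chain carbon bound to an aromatic carbon. They also leave open whether a phenyl carrying a single chlorine would follow compound 2 or compound 3 more closely.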